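The source may hold more compounds than are shown below. What is called first, only, known or untested is meant among the compounds shown, and "the series" means these compounds.

Values in a functional assay on HCT-116 cells (Homo sapiens) for antiproliferative activity, read by MTT assay, with a stated time of 48 h; a lower number here means a stronger inhibitor, a higher number a weaker inhibitor:
Compound 1 `CCCCCC(CCO)n1cnc2c(N)nc(Cl)nc21`: > 50000 nM, a limit.
Compound 2 `CCCCCCC(CCO)n1cnc2c(N)nc(Cl)nc21`: > 50000 nM, a limit.
Compound 3 `CCCCCCCCCCC(CCO)n1cnc2c(N)ncnc21`: 2590 nM.

Among the compounds with values here, compound 3 gives the only actual number in this assay, 2590 nM. The values of compound 1 and compound 2 are limits only. Compound 4 `CCCCCCCCCCC(CCO)n1cnc2c(N)nc(Cl)nc21` differs from compound 3 by a single change, (chloro in place of hydrogen on an aromatic carbon). Within the data shown here, the one measured step, a step that the two limits leave unreadable from compound 1 to compound 2, gives no size and concerns the chain rather than the chloro. Compound 1 and compound 2 both carry the chloro, but they also differ from compound 3 in the chain, so the effect of the chloro alone is unmeasured. No step beyond the scatter is therefore expected, though the range is wide. The expected step is a 1.5-fold higher number from compound 3 to compound 4 (0.19 log units; within the scatter). Compound 4 is estimated at 4000 nM, within an expected range of 1000 nM to 20000 nM.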

Compound 4, half-maximal inhibitory concentration: 11800 nM
The estimate for compound 4 lay 3.0-fold (0.47 log units) below the measured number; low and high end bracket the measured number.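

In this assay, replacing hydrogen with chloro on the aromatic carbon between two ring nitrogen atoms now has a readable size, and it weakens inhibition (a 4.6-fold higher number from compound 3 to compound 4 (0.66 log units; beyond the scatter)). With the chloro kept, the chain also proves to matter, since butyl in place of hydrogen strengthens inhibition (an at least 4.2-fold lower number from compound 2 to compound 4 (0.62 log units; beyond the scatter)), as does pentyl in place of hydrogen (an at least 4.2-fold lower number from compound 1 to compound 4 (0.62 log units; beyond the scatter)). Both of these chain steps have only a minimum size: the limit of > 50000 nM in this assay, at which 2 of the 4 values shown sit. From the compounds shown here alone, it remains open whether an amine or a methoxy at this aromatic carbon would give a stronger or weaker inhibitor than hydrogen or chloro. Going by these compounds, it also remains open whether a longer chain would strengthen inhibition further.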